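A few compounds are considered here, and "the series" means these few. Any claim that something is new, unique, unknown or untested is made for them only; others in the source may bear on it.

Measured compounds:
- compound 1 `Cc1cc(NC(=O)Cn2nnc(-c3ccccc3)n2)n(C(C)C)n1`: in an assay on HEK293 cells for activation of Kir3.1/Kir3.2 (Homo sapiens), read by thallium flux (a lower number here means that less compound is needed, a higher number that more compound is needed for the effect), compound 1 gives 556 nM
- compound 2 `O=C(Cn1nnc(-c2ccccc2)n1)Nc1cc(C2(C(F)(F)F)CC2)nn1C1CCCCC1`: in this assay compound 2 is reported as "not active" (no number reported), with no number given

For the measured compounds named here, compound 1 holds the only numerical result in this assay so far; compound 2 stands beside it only as an inactive entry, and the two differ in more than one place, so nothing further can be read from that pair.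

Compound 3 `Cc1cc(NC(=O)Cn2nnc(-c3ccccc3)n2)n(CC2CCCCC2)n1` has not yet been measured. It differs from compound 1 in one place: cyclohexylmethyl in place of isopropyl on an aromatic nitrogen. Going by the values given here, the group that enters is larger than the one that leaves, and the only other compound carrying a ring on that aromatic nitrogen, compound 2, was not active.

Among the compounds with values here, no step between measured compounds is available to guide the size of this change. A modest loss, beyond the usual scatter, is expected from compound 1 to compound 3, a 2.3-fold higher number from compound 1 to compound 3 (0.37 log units; beyond the scatter). Compound 3 is therefore estimated at 1300 nM in this assay, within a range from 400 nM to 4500 nM.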

Compound 3, half-maximal effective concentration: 176 nM
Estimate against measurement, compound 3: 7.4-fold (0.87 log units) above, outside the stated range (below it).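

In this assay, the aromatic nitrogen of the shared core accepts a larger group with a gain rather than a loss: cyclohexylmethyl in place of isopropyl gives a 3.2-fold lower number from compound 1 to compound 3 (0.50 log units; beyond the scatter), so less compound is needed for the effect. For the compounds shown here, this is the first step that changes only this position, and it shows that a six-membered non-aromatic ring of carbon only, carried on this nitrogen through one extra carbon, is compatible with a measured activity. No available measurement explains why the number falls.

A single step cannot show whether the gain follows from the ring itself or simply from the added carbon atoms. It also leaves open how a straight hexyl chain, a benzyl group or a cyclohexyl ring bonded directly to this nitrogen would compare on the same core.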